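The compounds below may be only part of what the source reports. "The series", "measured", "known", "first", "only" and "open" are said of these compounds alone.

Measured so far:
compound 1, `CC(=O)N1CCC[C@H](NS(C)(=O)=O)[C@@H]1CO[C@H]1CC[C@@H](c2ccccc2)CC1` — a functional assay on CHO-K1 cells for agonist activity at Orexin/Hypocretin receptor type 1 (Homo sapiens), read by FLIPR and calcium flux; a higher number here means that more compound is needed for the effect, a lower number that less compound is needed: > 100000 nM; > 100000 nM; > 100000 nM (3 entries)
compound 2, `CCOC(=O)N1CCC[C@H](NS(C)(=O)=O)[C@@H]1CO[C@H]1CC[C@@H](c2ccccc2)CC1` — in this assay: > 100000 nM

Every entry shown for compound 1 is a limit of the assay, not a number. For compound 2 the single entry in this assay is likewise a limit, (the limit of > 100000 nM in this assay, at which 1 of the 2 values shown sits), so compound 2 cannot be placed on a scale of numbers at all; it stands only at the edge of what this assay reports.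

Compound 3, `CCNC(=O)N1CCC[C@H](NS(C)(=O)=O)[C@@H]1CO[C@H]1CC[C@@H](c2ccccc2)CC1`, differs from compound 2 by ethylamino in place of ethoxy on a carbonyl carbon; cut one bond further out, ethoxycarbonyl becomes ethylcarbamoyl. No step between two measured compounds exists in this set: compound 1 and compound 2 differ in another place and both sit at the limit, so nothing shown points in either direction. The expectation for compound 3 is therefore no step beyond the scatter, a number no higher from compound 2 to compound 3 (the limit leaves the size open), with a further limit the most likely outcome. Compound 3 is expected to give 100000 nM in this assay, within a range of 30000 nM to 300000 nM.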

Compound 3, half-maximal effective concentration: > 14000 nM
Compound 3 was reported as a limit (the forecaster's own chance of this, stated with the estimate: 85%); the middle value is on the limit's open side.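

In this assay compound 2 gives > 100000 nM, a limit of the assay. Compound 3 gives > 14000 nM, also a limit, so no step can be read between compound 2 and compound 3. The compounds shown leave open whether ethylamino in place of ethoxy changes the response, and whether any compound in this series gives a measurable number in this assay.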